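Swapping one side group on compound 1

A few compounds are considered here, and "the series" means these few. Any claim that something is new, unique, unknown or untested is made for them only; others in the source may bear on it.

In a toxicity assay on Huh-7.5 cells (Homo sapiens) for inhibition, read by MTT assay, with a stated time of 96 h (a lower number here means that less compound is tolerated, a higher number that more compound is tolerated), compound 1 (`CC1CCN(c2ccc(NC(=O)c3ccc(OCCCCl)c([N+](=O)[O-])c3)cn2)CC1`) gives 9200 nM and holds the second highest of three numbers. Above it lies compound 2 (`COc1ccc(C(=O)Nc2ccc(N(C)C)cc2)cc1[N+](=O)[O-]`) with 88200 nM as its number, and below it lies compound 3 (`CN1CCN(Cc2ccc(NC(=O)c3ccc(OCCCCCCl)c([N+](=O)[O-])c3)cc2C(F)(F)F)CC1`) with 2140 nM as its number. Compound 4 (`CN1CCN(Cc2ccc(NC(=O)c3ccc(OCCCCl)c([N+](=O)[O-])c3)cn2)CC1`) carries (4-methylpiperazin-1-yl)methyl in place of 4-methylpiperidin-1-yl on an aromatic carbon. Among the compounds with values here, no measured pair differs in one place only, so this change has no direct precedent. Compound 3 also carries (4-methylpiperazin-1-yl)methyl but differs from compound 1 elsewhere too, so its number cannot show what this group alone does. In this assay the expected step (a 1.3-fold higher number from compound 1 to compound 4 (0.12 log units; within the scatter)) is small and stays within the scatter. Compound 4 is estimated at 12000 nM within an expected range (5000 nM to 30000 nM).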

Compound 4, half-maximal cytotoxic concentration: 12600 nM
Beside the measured number, compound 4's estimate is 1.1-fold (0.02 log units) below it, within the range that was stated.
By their numbers in this assay, from the lowest: compound 3; then compounds 1 and 4 (each within the scatter of the next); then compound 2.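

In this assay, within the data shown here, the one-place swap gives a 1.4-fold higher number from compound 1 to compound 4 (0.14 log units; within the scatter), the first direct reading of a change at this position, and it does not separate the two compounds. On this aromatic carbon next to the ring nitrogen, (4-methylpiperazin-1-yl)methyl, with two hetero atoms in its ring, therefore reads the same as 4-methylpiperidin-1-yl, with one. Nothing measured here gives a reason for this. As far as these compounds go, whether a morpholine ring or a carboxylic acid at this position would also stay within the scatter of compound 1 remains open.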